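The compounds below may be only part of what the source reports. "The series", "measured", "known", "first", "only" and "open" are said of these compounds alone.

In a functional assay on THP-1 cells (Homo sapiens) for inhibition, read by sulforhodamine B assay, tested at 100 uM (a higher number here means more inhibition of growth at the concentration tested, a lower number less inhibition of growth), compound 2 `COc1ccc(C2CC(c3ccc(OCc4cn(Cc5ccc([N+](=O)[O-])cc5)nn4)cc3)=NN2C(C)=O)cc1` gives 26%, the second highest of the three numbers. Compound 3 `COc1cc(C2CC(c3ccc(Br)cc3)=NN2C(C)=O)ccc1OCc1cn(Cc2ccc([N+](=O)[O-])cc2)nn1` gives 23%, within the scatter of compound 2, while compound 1 `COc1cc(C2CC(c3cccc4ccccc34)=NN2C(C)=O)ccc1OCc1cn(Cc2ccc([N+](=O)[O-])cc2)nn1` gives 79%, beyond the scatter above it. Among the measured compounds shown here, the only step measured in one place, a number 56 percentage points lower from compound 1 to compound 3 (beyond the scatter), concerns a group on a carbon with a double bond to nitrogen, not the ring that compound 4 `COc1ccc(C2CC(c3ccc(OCc4cn(Cc5ccc([N+](=O)[O-])cc5)nn4)cc3)=NN2C(C)=O)cc1OC` alters: methoxy in place of hydrogen on an aromatic carbon. For the measured compounds named here, no measured step bears on methoxy in place of hydrogen on this ring, so no step beyond the scatter is expected in this assay. Compound 4 is therefore estimated at 30%, with a range from 10% to 55%. The step of a number 4 percentage points higher from compound 2 to compound 4 (within the scatter) is expected to stay within the scatter.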

Compound 4, percent growth inhibition at one concentration: 9%
Estimate against measurement, compound 4: 21 percentage points above, outside the stated range (below it).
By their numbers in this assay, from the lowest: compound 4; then compounds 3 and 2 (each within the scatter of the next); then compound 1.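

In this assay, 4-methoxyphenyl changing to 3,4-dimethoxyphenyl is not a silent change: methoxy in place of hydrogen gives a number 17 percentage points lower from compound 2 to compound 4 (beyond the scatter). Among the compounds shown here, this is the first step read on this ring, and it shows that the position ortho to a methoxy group and meta to a large group responds in this assay, in a modest step. Nothing available explains the drop. The compounds shown leave open whether a hydroxy group or a chlorine atom at this position would lower the number too, and whether methoxy has the same effect on other cores.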